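This account rests on a few compounds, and the source may have more. Where it says the series, first, only, none or still open, it means among the compounds named here.

Measured so far:
Compound 1, `CN1CCC(NC(=O)Nc2cccc3[nH]ncc23)c2cc(C(C)(C)C)ccc21`, gives 853 nM in a functional assay for antagonist activity at transient receptor potential cation channel subfamily V member 1 (Homo sapiens), read by calcium flux; a lower number here means a stronger inhibitor, a higher number a weaker inhibitor.
Compound 2, `O=C(Nc1cccc2[nH]ncc12)NC1CCN(Cc2ccccc2)c2ccc(F)cc21`, gives 66 nM in this assay.

Of these two numbers, compound 2 has the lower one, so it is the stronger inhibitor of the pair; the number for compound 1 is higher by a margin well beyond the usual scatter of this assay. Within the data shown here, compound 1 and compound 2 differ in more than one place, so no single structural step connects them, and their two values can only be set side by side.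

Compound 3, `CC(C)(C)c1ccc2c(c1)C(NC(=O)Nc1cccc3[nH]ncc13)CCN2Cc1ccccc1`, is not yet measured. It keeps the whole of compound 2 except for one change: tert-butyl in place of fluoro on an aromatic carbon. Whether the tert-butyl group or the other difference between compound 1 and compound 2 accounts for their gap cannot be told from the two numbers alone, so the expected direction of this step is uncertain. The step from compound 2 to compound 3 is expected to be small, a 1.8-fold higher number from compound 2 to compound 3 (0.26 log units; within the scatter), likely a modest loss or none beyond the scatter. Compound 3 is thus estimated at 120 nM, with a range from 35 nM to 450 nM.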

Compound 3, half-maximal inhibitory concentration: 121 nM
Beside the measured number, compound 3's estimate is 1.0-fold (0.00 log units) below it; low and high end bracket the measured number.
By their numbers in this assay, from the lowest: compounds 2 and 3 (each within the scatter of the next); then compound 1.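

Swapping fluoro for tert-butyl on this aromatic carbon gives a 1.8-fold higher number from compound 2 to compound 3 (0.26 log units; within the scatter) in this assay, so this position accepts a group of four heavy atoms as well as one of a single heavy atom, with no difference that stands out from the scatter. Among these compounds, the earlier gap between compound 1 and compound 2 can now be partly placed: with tert-butyl held constant, phenyl in place of hydrogen on the saturated chain carbon bound to the ring nitrogen gives a 7.0-fold lower number from compound 1 to compound 3 (0.85 log units; beyond the scatter) and is the only step here that lies beyond the scatter. No measurement here explains why either step turns out as it does.

Only fluoro and tert-butyl are shown at the aromatic carbon, so it remains open whether a methoxy group, a nitrile or an amine would also stay within the scatter of compound 2. On these data alone, it also remains open whether the phenyl step would be of similar size with fluoro on the aromatic ring, and how a pyridine ring or a longer chain would compare with the phenyl.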